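Furanyl replacement at the carbinol carbon in compound 3

The source may report more compounds than this note shows. Statements on the series, on what has been measured and on what is new or still open speak of the compounds shown alone.

For the measured compounds named here, in a functional assay on WHCO1 cells (Homo sapiens) for cytotoxicity, read by MTT assay, with a stated time of 24 h (a higher number here means a weaker inhibitor, a lower number a stronger inhibitor), compound 2 `O=C1C=C(C(O)c2cccc(Cl)c2)C(=O)c2ccccc21` gives 7300 nM, the highest of the two numbers so far. Compound 1 `O=C1C=C(C(O)c2ccccc2)C(=O)c2ccccc21` gives 3900 nM in this assay, and the step of a 1.9-fold higher number from compound 1 to compound 2 (0.27 log units; within the scatter) lies within the scatter. Compound 3 `O=C1C=C(C(O)c2ccoc2)C(=O)c2ccccc21` differs from compound 2 by furan-3-yl in place of 3-chlorophenyl on a saturated chain carbon bound to a double-bonded ring carbon and an oxygen on a saturated carbon. Going by the values given here, no measured step swaps one aromatic ring for another; the only step available, a 1.9-fold higher number from compound 1 to compound 2 (0.27 log units; within the scatter), alters a ring substituent and was within the scatter, so it bears only loosely on this change. No step beyond the scatter is expected, as a 1.3-fold lower number from compound 2 to compound 3 (0.12 log units; within the scatter). Compound 3 is estimated at 5500 nM, range 2000 nM to 15000 nM.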

Compound 3, half-maximal inhibitory concentration: 10900 nM
For compound 3 the middle estimate is 2.0-fold (0.30 log units) below the measured one, and the stated range covers the measured number.
By their numbers in this assay, from the lowest: compounds 1, 2 and 3 (each within the scatter of the next, the first and the last beyond it).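

In this assay this position now shows its first step beyond the scatter, though a modest one: furan-3-yl in place of phenyl weakens the compound (a 2.8-fold higher number from compound 1 to compound 3 (0.45 log units; beyond the scatter)). Set against 3-chlorophenyl, the same ring gives a step within the scatter (a 1.5-fold higher number from compound 2 to compound 3 (0.17 log units; within the scatter)), so furan-3-yl and 3-chlorophenyl are not separated here. No evidence bears on the cause of the step from phenyl.

Open, from the compounds shown here alone, is whether the ring oxygen or the smaller ring size matters. Also open, going by these compounds, is how a saturated cyclohexyl group or an aminomethyl-substituted phenyl would read at this position.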